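This account rests on a few compounds, and the source may have more. Where it says the series, first, only, none or still open, it means among the compounds named here.

Measured in an ADME assay on MT4 cells (Homo sapiens) for cytotoxicity, read by MTT assay, with a stated time of 5 days; a lower number here means that less compound is tolerated, a higher number that more compound is tolerated:
- compound 1 `N#Cc1ccc(Nc2nccc([C@@H](O)c3ccc(-c4ccc(C#N)cc4)cc3F)n2)cc1`: 7500 nM
- compound 2 `Cc1cc(-c2ccc(C#N)cc2)ccc1[C@H](O)c1ccnc(Nc2ccc(C#N)cc2)n1`: 4000 nM
- compound 3 `N#Cc1ccc(Nc2nccc(C(O)c3ccc(-c4ccc(C#N)cc4)cc3C(F)(F)F)n2)cc1`: 11400 nM

Compound 3 lies within the scatter of compound 1, and its number is higher than that of compound 2 by more than the scatter. Compound 4 `N#Cc1ccc(Nc2nccc([C@@H](O)c3ccc(-c4ccc(C#N)cc4)cc3C(F)(F)F)n2)cc1` has the same atoms and bonds as compound 3: the two compounds have the same atoms and bonds; at least one stereo element is drawn with a configuration in one of them and without one in the other: 1 of 1 stereo elements differ; a stereocentre at a saturated chain carbon is drawn without a configuration in compound 3 and S in compound 4. The stereocentre at a saturated chain carbon is drawn without a configuration in compound 3 and S in compound 4. Among the measured compounds shown here, the only measured step, a 1.9-fold lower number from compound 1 to compound 2 (0.27 log units; within the scatter), is methyl in place of fluoro and leaves that stereocentre unchanged. For the measured compounds named here, no measured pair isolates such a stereo difference, so the estimate rests on compound 3 at 11400 nM. No change beyond the scatter is expected in this assay, and the expected step is a 1.1-fold lower number from compound 3 to compound 4 (0.06 log units; within the scatter). Compound 4 is expected at 10000 nM, with an estimated range of 5000 nM to 20000 nM.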

Compound 4, half-maximal cytotoxic concentration: 9780 nM
For compound 4 the middle estimate is 1.0-fold (0.01 log units) above the measured one; the measured number falls inside the stated range.
By their numbers in this assay, from the lowest: compounds 2, 1, 4 and 3 (each within the scatter of the next, the first and the last beyond it).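

In this assay, drawing the stereocentre as S gives no change beyond the scatter: a 1.2-fold lower number from compound 3 to compound 4 (0.07 log units; within the scatter). Among the compounds shown here, at the aromatic carbon, trifluoromethyl in place of methyl gives the first step here beyond the scatter, though a modest one: a 2.4-fold higher number from compound 2 to compound 4 (0.39 log units; beyond the scatter). Trifluoromethyl in place of fluoro stays within it: a 1.3-fold higher number from compound 1 to compound 4 (0.12 log units; within the scatter).

The compounds shown leave open how the opposite configuration at the stereocentre would stand in this assay. They also leave open how an amine or a carboxylic acid on that aromatic carbon would stand there.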